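Adding a Group to the Aromatic Hydroxy of Compound 1

The source may report more compounds than this note shows. Statements on the series, on what has been measured and on what is new or still open speak of the compounds shown alone.

Compound 1 (`Cc1c(C)c2c(c(C)c1O)CC(CCn1ccc(=O)c(O)c1C)O2`) has no exact place on the scale yet. In an ADME assay for solubility (a higher number here means a more soluble compound, a lower number a less soluble compound), compound 1 gives < 100 ug/mL as a limit of the assay and not a number. Compound 2 (`Cc1c(C)c2c(c(C)c1O)CCC(C)(CNCCCCn1ccc(=O)c(O)c1C)O2`) gives < 100 ug/mL as the same kind of limit. The two measured compounds thus share one result (the limit of < 100 ug/mL in this assay, at which 2 of the 2 values shown sit) and nothing finer can be read from them.

Compound 3 (`CNCC(=O)Oc1c(C)c(C)c2c(c1C)CC(CCn1ccc(=O)c(O)c1C)O2`) differs from compound 1 by having ((methylamino)methyl)carbonyl in place of hydrogen on an oxygen on an aromatic ring and the rest of the structure stays the same. Among the compounds with values here, no measured pair shows this change directly, so the forecast is uncertain. An upward move beyond the usual scatter is expected in this assay and an at least 2.5-fold higher number from compound 1 to compound 3 (0.39 log units; beyond the scatter) is its estimated size. For compound 3 the estimated solubility is 250 ug/mL with a range from 80 ug/mL to 1000 ug/mL as the likely span.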

Compound 3, solubility: > 20000 ug/mL
Compound 3 was reported as a limit; the forecaster's own chance of this, stated with the estimate: 35%; middle value at least 80-fold (1.90 log units) away from the limit.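

Putting ((methylamino)methyl)carbonyl in place of hydrogen on an oxygen on an aromatic ring gives, in this assay, an at least 200-fold higher number from compound 1 to compound 3 (2.30 log units; beyond the scatter). Compound 3 gives > 20000 ug/mL, which is a limit of the assay and not a number. Compound 1 and compound 2 both carry the free hydroxy and could not be told apart, whereas this single change on that oxygen moves the structure from the shared limit to the opposite end of the values shown: the limit of > 20000 ug/mL in this assay, at which 1 of the 3 values shown sits.

From the compounds shown here alone, what a plain acetyl group, without the amine, would give on the same oxygen stays open, as does a longer chain carrying the amine. Going by these compounds, with no exact number for compound 1 or compound 3, the true size of the step also remains unknown.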